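The source may hold more compounds than are shown below. What is called first, only, known or untested is meant among the compounds shown, and "the series" means these compounds.

Measured compounds:
- Compound 1, `Cc1nc(N)sc1CCCN/C(N)=N/C(=O)NCC(C)CCc1ccccc1`: 63.1 nM in an assay on membranes from Sf9 cells for displacement of a labelled ligand from histamine H2 receptor (Homo sapiens), read by scintillation counting, with a stated time of 60 min; a higher number here means a weaker inhibitor, a lower number a stronger inhibitor
- Compound 2, `CCCNC(=O)/N=C(\N)NCCCc1sc(N)nc1C`: 105 nM
- Compound 3, `Cc1ccc(C(C)NC(=O)/N=C(\N)NCCCc2sc(N)nc2C)cc1`: 30.9 nM

Compound 2 shows the highest number of the three. Compound 1 sits nearest, and the step of a 1.7-fold higher number from compound 1 to compound 2 (0.22 log units; within the scatter) is within the scatter, so the two are not told apart. Within the data shown here, compound 3 stands furthest from compound 2, with a number low enough that the gap lies beyond the scatter; no single step links those two compounds, so only the two values themselves speak here.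

Compound 4, `Cc1nc(N)sc1CCCN/C(N)=N/C(=O)NCc1ccccc1`, is not yet measured. It differs from compound 2 in one place: phenyl in place of ethyl on a saturated chain carbon bound to an amide-type nitrogen. Among the measured compounds shown here, the only measured step bearing on this is the one from compound 1 to compound 2, where removing a phenethyl group from the chain left the number essentially unchanged. The shared core is the same throughout, and the two compounds carrying an aromatic ring on the chain, compound 1 and compound 3, both give lower numbers than compound 2. A modest lowering is therefore expected, of a size that may or may not clear the scatter; this gives an expected 2.3-fold lower number from compound 2 to compound 4 (0.37 log units; beyond the scatter). Compound 4 is expected to give 45 nM, within a range from 15 nM to 130 nM.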

Compound 4, inhibition constant: 69.2 nM
Beside the measured number, compound 4's estimate is 1.5-fold (0.19 log units) below it, within the range that was stated.
By their numbers in this assay, from the lowest: compound 3; then compounds 1, 4 and 2 (each within the scatter of the next).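

In this assay, the ethyl end of the chain in compound 2 can give way to phenyl, which turns propyl into benzyl, and the step is a 1.5-fold lower number from compound 2 to compound 4 (0.18 log units; within the scatter). Among these compounds, the earlier step showed only that losing a phenethyl group from a carbon further along the chain could not be told from the scatter; this one shows the same for an aromatic ring set on the saturated chain carbon bound to the amide-type nitrogen. At this position, then, a propyl and a benzyl group are not told apart, even though the second brings a whole six-membered aromatic ring, and nothing shown gives a reason for this result.

Compound 3 differs from compound 4 in more than one place, so compound 3, at 30.9 nM, cannot be tied to any single change. Still open, as far as these compounds go, is how this position would respond to a different kind of group, such as an amine, a carboxylic acid or a hydroxyl, and whether a phenyl ring carrying fluorine or methoxy would give a step beyond the scatter.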